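Cyclopentyl to cyclohexyl on the triazole nitrogen of xanthine analogues

The source may report more compounds than this note shows. Statements on the series, on what has been measured and on what is new or still open speak of the compounds shown alone.

Measured compounds:
compound 1, `Cn1c(=O)c2nn(C3CCCC3)nc2n(C)c1=O`, 110000 nM
compound 2, `Cn1c(=O)c2nn(C3CCCCC3)nc2n(C)c1=O`, 36000 nM
compound 3, `CCCn1c(=O)c2nn(C3CCCC3)nc2n(CCC)c1=O`, 1300 nM

Three compounds share a fused core and have been run in an assay on cell membranes from brain for displacement of a labelled ligand from adenosine receptor A1 (Bos taurus); a lower number here means a stronger inhibitor, a higher number a weaker inhibitor. Compound 1 gives 110000 nM and compound 2 gives 36000 nM; the change between them is cyclohexyl in place of cyclopentyl on an aromatic nitrogen and it gave a 3.1-fold lower number from compound 1 to compound 2 (0.49 log units; beyond the scatter). Compound 3 carries propyl groups where compounds 1 and 2 carry methyl groups, and in this assay compound 3 gives 1300 nM; how its core differs from that of compound 1 is not broken down here.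

Compound 4, `CCCn1c(=O)c2nn(C3CCCCC3)nc2n(CCC)c1=O`, has not been measured. It differs from compound 3 by cyclohexyl in place of cyclopentyl on an aromatic nitrogen, the same change as from compound 1 to compound 2, seen twice in this set. Because a 3.1-fold lower number from compound 1 to compound 2 (0.49 log units; beyond the scatter), the step is expected to be a 2.9-fold lower number from compound 3 to compound 4 (0.46 log units; beyond the scatter). Compound 4 is therefore expected to give about 450 nM in this assay. For compound 4 the expected range runs from 150 nM to 1300 nM, allowing for the change acting somewhat differently on the dipropyl core than on the dimethyl one.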

Compound 4, inhibition constant: 1600 nM
Compound 4: middle estimate off by 3.6-fold (0.55 log units), on the low side, outside the stated range (above it).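

In this assay, cyclohexyl in place of cyclopentyl on the aromatic nitrogen gives a 1.2-fold higher number from compound 3 to compound 4 (0.09 log units; within the scatter), so compound 3 and compound 4 cannot be told apart in this assay. The step seen on the core of compound 1 therefore does not carry over unchanged to the core of compound 3: the same change on two cores in this assay, a 3.1-fold lower number (0.49 log units; beyond the scatter) from compound 1 to compound 2 and a 1.2-fold higher number (0.09 log units; within the scatter) from compound 3 to compound 4, 3.8-fold (0.58 log units) apart, beyond the scatter of two such steps. This rests on one pair per core, so it shows that the effect of this change depends on the core in these four compounds, but it does not show that propyl in place of methyl is what alters the step, nor how the change would behave on any other core.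

On these data alone, whether a cycloheptyl or a phenyl group on the same aromatic nitrogen would separate the two cores further remains open. So does whether a longer chain such as butyl in place of propyl would restore a step of the size seen from compound 1 to compound 2.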